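Swapping the Five-Membered Ring on the Chlorophenyl Arm

This account rests on a few compounds, and the source may have more. Where it says the series, first, only, none or still open, it means among the compounds named here.

Measured so far:
compound 1, `Cn1nc2c(=O)n(CC3(O)CCN(Cc4ccc(-c5cnco5)cc4Cl)CC3)cnc2c1-c1ccc(CN)cc1`, 71.6 nM
compound 2, `Cn1cc(-c2ccc(CN3CCC(O)(Cn4cnc5c(-c6ccc(CN)cc6)n(C)nc5c4=O)CC3)c(Cl)c2)cn1`, 291 nM

Both compounds were tested in an assay on isolated protein for inhibition of ubiquitin carboxyl-terminal hydrolase 7 (Homo sapiens), with stated times of 30 min and 2 h; on this read-out lower numbers stand for stronger inhibition and higher numbers for weaker inhibition. Compound 2 has the highest of the two numbers shown, so it is the weaker inhibitor of the pair; its only neighbour is compound 1, and the single measured step, a 4.1-fold higher number from compound 1 to compound 2 (0.61 log units; beyond the scatter), shows that exchanging one small five-membered ring for another at the same position can move the number by a modest amount.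

Compound 3, `Cn1nc2c(=O)n(CC3(O)CCN(Cc4ccc(-c5ccc[nH]5)cc4Cl)CC3)cnc2c1-c1ccc(CN)cc1`, carries a further exchange at that same position: 1H-pyrrol-2-yl in place of 1-methyl-1H-pyrazol-4-yl on an aromatic carbon. The ring enters on an aromatic carbon of a six-membered aromatic ring of carbon only, meta to a chloro group and para to a large group.

Within the data shown here, only the step from compound 1 to compound 2 bears on this change, and it does so loosely, since a different ring enters here. The new ring resembles the ring of compound 1 in being small and five-membered, so a modest move toward a lower number is expected, though a result within the scatter of compound 2 would not surprise. Compound 3 is therefore estimated at 150 nM, with a range of 50 nM to 450 nM, which means an expected step of a 1.9-fold lower number from compound 2 to compound 3 (0.29 log units; within the scatter).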

Compound 3, half-maximal inhibitory concentration: 193 nM
Estimate against measurement, compound 3: 1.3-fold (0.11 log units) below; the measured number falls inside the stated range.
By their numbers in this assay, from the lowest: compound 1; then compounds 3 and 2 (each within the scatter of the next).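

In this assay, the exchange of 1-methyl-1H-pyrazol-4-yl for 1H-pyrrol-2-yl gives a 1.5-fold lower number from compound 2 to compound 3 (0.18 log units; within the scatter), so these two rings cannot be told apart here, even though the entering ring carries a hydrogen-bond donor that the leaving ring lacks. The 1,3-oxazol-5-yl ring now stands apart from both of the others: alongside the earlier 4.1-fold higher number from compound 1 to compound 2 (0.61 log units; beyond the scatter), there is now a 2.7-fold higher number from compound 1 to compound 3 (0.43 log units; beyond the scatter), which makes compound 1 the strongest inhibitor of the three. No measurement at hand accounts for this gap between the 1,3-oxazol-5-yl ring and the other two rings.

The compounds shown leave open how this position responds to a group that is not a small five-membered aromatic ring, such as a nitrile, an amine or a carboxylic acid. As far as these compounds go, every compound here also keeps the chloro group and the same core, so it remains open whether the gap would survive if either were changed.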